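This account rests on a few compounds, and the source may have more. Where it says the series, first, only, none or still open, it means among the compounds named here.

Working notes on the series. Compound 1 `COc1ccc(C2CC(c3ccccc3)=NN2C2=NC(=O)/C(=C3\C(=O)Nc4ccc(Br)cc43)S2)cc1` and compound 2 `COc1ccc(C2=NN(C3=NC(=O)/C(=C4\C(=O)Nc5ccc(Br)cc54)S3)C(c3ccc(OC)cc3)C2)cc1` share one core; compound 2 differs from compound 1 by methoxy in place of hydrogen on an aromatic carbon. In a functional assay on cells (Cancer cell lines, Homo sapiens) for cytotoxicity, read by sulforhodamine B assay, with a stated time of 48 h (on this read-out higher numbers stand for weaker inhibition of growth and lower numbers for stronger inhibition of growth), compound 1 gives 390 nM and compound 2 gives 405 nM, a step of a 1.0-fold higher number from compound 1 to compound 2 (0.02 log units; within the scatter). Compound 3 `O=C1N=C(N2N=C(c3ccccc3)CC2c2ccc(Cl)cc2)S/C1=C1/C(=O)Nc2ccccc21` is built on another core; the difference between the two cores is not broken down here. In this assay compound 3 gives 500 nM, a number that lies within the scatter of both compound 1 and compound 2, so no order among the three is claimed.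

Compound 4 `COc1ccc(C2=NN(C3=NC(=O)/C(=C4\C(=O)Nc5ccccc54)S3)C(c3ccc(Cl)cc3)C2)cc1` is not yet measured. It differs from compound 3 by methoxy in place of hydrogen on an aromatic carbon, the same change as from compound 1 to compound 2 and at the same place. Among the measured compounds shown here, only one earlier instance of this change is known, so the expectation rests on it alone. For compound 4 a step of no change at the digits printed from compound 3 to compound 4 (within the scatter) is expected in this assay because the earlier instance gave a 1.0-fold higher number from compound 1 to compound 2 (0.02 log units; within the scatter). Compound 4 is therefore estimated at 500 nM, with an expected range from 300 nM to 850 nM.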

Compound 4, concentration for total growth inhibition: 100000 nM
Compound 4: the middle estimate sits 200-fold (2.30 log units) below what was measured, and the stated range ends below it.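

In this assay methoxy in place of hydrogen gives a 200-fold higher number from compound 3 to compound 4 (2.30 log units; beyond the scatter) and so a large weakening of growth inhibition on the core of compound 3. The change therefore does not carry over unchanged from one core to the other in this series: the same change on two cores in this assay, a 1.0-fold higher number (0.02 log units; within the scatter) from compound 1 to compound 2 and a 200-fold higher number (2.30 log units; beyond the scatter) from compound 3 to compound 4, 190-fold (2.28 log units) apart, beyond the scatter of two such steps. Among the compounds shown here, this shows that, for these two pairs, the result of phenyl to 4-methoxyphenyl cannot be read across between the cores, but it does not show which difference between the cores matters, as compound 1 and compound 3 differ in more than one place and only one pair stands on each core.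

Still open, on these data alone, is whether the sharp step on the core of compound 3 is particular to methoxy or would also appear with a hydroxy group, an amine or a longer alkoxy chain at the same place. Also open is whether the bromine or the chlorine of these compounds has any part in the contrast between the two pairs.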